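Cyano for trifluoromethyl: working notes on the series

A few compounds are considered here, and "the series" means these few. Any claim that something is new, unique, unknown or untested is made for them only; others in the source may bear on it.

Values from an ADME assay (liver) for metabolic stability, with Liver microsome (Canis lupus familiaris) as the target, read by LC-MS, using microsomes, with a stated time of 30 min, tested at 4 uM (on this read-out lower numbers stand for a less stable compound and higher numbers for a more stable compound), follow
- compound 1 `Cc1nc(N2CCN(C)CC2)c2nc(-c3ccccc3Cl)n(CCN3CCCC3=O)c2n1` gives 60%
- compound 2 `Cc1nc(N2CCN(C)CC2)c2nc(-c3ccccc3C(F)(F)F)n(C3CCOCC3)c2n1` gives 61%

Compound 2 lies within the scatter of compound 1, so these two numbers set no order between them. Next in line is compound 3 `Cc1nc(N2CCN(C)CC2)c2nc(-c3ccccc3C#N)n(C3CCOCC3)c2n1` which differs from compound 2 in one place cyano in place of trifluoromethyl on an aromatic carbon with cyano in place of trifluoromethyl on an aromatic carbon, ortho to a large group. Within the data shown here, no measured pair shows a change at this place, so the expectation rests on compound 2 at 61% alone. In this assay no step beyond the scatter is expected, in either direction. The expected step of a number 3 percentage points higher from compound 2 to compound 3 (within the scatter) is small, and its sign is uncertain. For compound 3 the estimated value is 64% within an expected range from 45% to 82% on present evidence.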

Compound 3, percent of the compound remaining: 11%
The estimate for compound 3 lay 53 percentage points above the measured number; measured number below the stated range.
By their numbers in this assay, from the lowest: compound 3; then compounds 1 and 2 (each within the scatter of the next).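

In this assay this place on the aromatic ring proves sensitive: cyano in place of trifluoromethyl on an aromatic carbon, ortho to a large group, gives a number 50 percentage points lower from compound 2 to compound 3 (beyond the scatter) with the rest of the structure unchanged. Among these compounds, this is the first pair that differs at this place, and it shows that one substituent change there can move the read-out by a large step, which compound 1 and compound 2, lying within the scatter of each other, could not show. Nothing at hand bears on the origin of this step.

As far as these compounds go, it remains open whether the drop belongs to cyano alone or would also follow other groups here, such as methoxy or a primary amide. From the compounds shown here alone, it is also open whether the same change gives a step of similar size with a different group on the core, such as the side chain of compound 1.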